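The source may hold more compounds than are shown below. What is called first, only, known or untested is meant among the compounds shown, and "the series" means these compounds.

Compound 1 `CNC(=O)c1ccc(Oc2cccc(NC(=S)Nc3ccc(F)cc3)c2)nc1` carries a 4-fluorophenyl group on the thiourea nitrogen. In a functional assay on HCT-116 cells (Homo sapiens) for antiproliferative activity, read by MTT assay (on this read-out lower numbers stand for stronger inhibition and higher numbers for weaker inhibition), compound 1 gives 39400 nM, the highest of the three numbers measured. Its nearest neighbour is compound 3 `CNC(=O)c1ccc(Oc2cccc(NC(=S)Nc3ccc(Cl)cc3Cl)c2)nc1`, which gives 20900 nM; the step of a 1.9-fold lower number from compound 1 to compound 3 (0.28 log units; within the scatter) lies within the scatter. Furthest away stands compound 2 `CNC(=O)c1ccc(Oc2cccc(NC(=S)Nc3cc(C(F)(F)F)cc(C(F)(F)F)c3)c2)nc1`, which gives 2500 nM, a gap beyond the scatter, though no single-point step joins it to compound 1.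

Compound 4 `CNC(=O)c1ccc(Oc2cccc(NC(=S)Nc3ccc(F)c(F)c3)c2)nc1` is not yet measured. It differs from compound 1 by fluoro in place of hydrogen on an aromatic carbon. Among the measured compounds shown here, the only measured step that bears on it is the exchange of the aryl group, which stayed within the scatter, so one added fluoro is expected to move this assay little. Because the step of a 1.9-fold lower number from compound 1 to compound 3 (0.28 log units; within the scatter) was small, compound 4 is expected to give a number close to compound 1, with a 1.3-fold lower number from compound 1 to compound 4 (0.12 log units; within the scatter) as the expected step. The estimate for compound 4 is 30000 nM, with a range from 12000 nM to 70000 nM.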

Compound 4, half-maximal inhibitory concentration: 38200 nM
The estimate for compound 4 lay 1.3-fold (0.10 log units) below the measured number; low and high end bracket the measured number.
By their numbers in this assay, from the lowest: compound 2; then compounds 3, 4 and 1 (each within the scatter of the next).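

In this assay, a fluoro group on the aromatic carbon ortho to the existing fluoro group, which turns 4-fluorophenyl into 3,4-difluorophenyl, gives no readable change, with a 1.0-fold lower number from compound 1 to compound 4 (0.01 log units; within the scatter). The swap between 2,4-dichlorophenyl and 3,4-difluorophenyl also stays within the scatter, with a 1.8-fold higher number from compound 3 to compound 4 (0.26 log units; within the scatter), so compound 1, compound 3 and compound 4 cannot be told apart on these numbers. No other measurement is available that could account for this result.

Compound 2, with its two trifluoromethyl groups, gives 2500 nM, and the compounds shown leave open what a single trifluoromethyl group would give at this position. Also open, going by these compounds, is whether a larger change here, such as an amine or a carboxylic acid in place of the added fluoro group, would move the number beyond the scatter.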